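Fluoro in Place of Chloro: Compound 3 to Compound 4

The source may hold more compounds than are shown below. What is called first, only, known or untested is meant among the compounds shown, and "the series" means these compounds.

Compound 1 `C#CCN(Cc1ccc(OCc2cccc(F)c2)cc1)[C@@H](C)C(N)=O`: 7790 nM
Compound 2 `C[C@H](NCc1ccc(OCc2cccc(F)c2)cc1F)C(N)=O`: > 10000 nM, a limit of the assay
Compound 3 `C#CCN(Cc1ccc(OCc2cccc(F)c2)cc1Cl)[C@@H](C)C(N)=O`: 5600 nM

The read-out throughout is an assay on Sf9 cells for inhibition of Amine oxidase [flavin-containing] A (Homo sapiens), with stated times of 15 min and 60 min; on this read-out lower numbers stand for stronger inhibition and higher numbers for weaker inhibition. Among the compounds with values here, compound 3 gives 5600 nM in this assay, and compound 1 gives 7790 nM; the only measured one-change step between them is a 1.4-fold lower number from compound 1 to compound 3 (0.14 log units; within the scatter), so these two compounds cannot be told apart. For compound 2 the assay reports only a limit, (the limit of > 10000 nM in this assay, at which 1 of the 3 values shown sits), and no number.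

Compound 4 `C#CCN(Cc1ccc(OCc2cccc(F)c2)cc1F)[C@@H](C)C(N)=O` differs from compound 3 by fluoro in place of chloro on an aromatic carbon. Within the data shown here, no measured step here swaps these two halogens directly; the nearest guide is the hydrogen-to-chloro step, which stayed within the scatter. A fluoro group at the same carbon is therefore expected to leave the number about where compound 3 and compound 1 sit, with no shift beyond the scatter in this assay. The step of a 1.3-fold higher number from compound 3 to compound 4 (0.10 log units; within the scatter) is the expected outcome of that change. Compound 4 is thus expected to give about 7000 nM in this assay, with a likely range from 3500 nM to 14000 nM.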

Compound 4, half-maximal inhibitory concentration: 8710 nM
The estimate for compound 4 lay 1.2-fold (0.09 log units) below the measured number; low and high end bracket the measured number.
By their numbers in this assay, from the lowest: compounds 3, 1 and 4 (each within the scatter of the next). At a limit, above all of these: compound 2.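

In this assay, the aromatic carbon ortho to a large group can now be compared with three different occupants: swapping the halogen gives a 1.6-fold higher number from compound 3 to compound 4 (0.19 log units; within the scatter), and replacing hydrogen with fluoro gives a 1.1-fold higher number from compound 1 to compound 4 (0.05 log units; within the scatter). Hydrogen, chloro and fluoro at this carbon therefore cannot be told apart in compound 1, compound 3 and compound 4, and exchanging one of these small occupants for another leaves the number within the scatter. Compound 2 stands at a limit of the assay, so the step that adds propargyl on the amine nitrogen, an at least 1.1-fold lower number from compound 2 to compound 4 (0.05 log units; that floor lies within the scatter), offers only a floor and cannot be read as a true size: the limit of > 10000 nM in this assay, at which 1 of the 4 values shown sits.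

Going by these compounds, whether a methoxy, nitrile or trifluoromethyl group at this carbon would move the number beyond the scatter stays open, as does the outcome of a longer chain in place of propargyl on the amine nitrogen. Within the data shown here, it is also open whether propargyl itself matters here, for the only comparison without it ends at a limit.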